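Amide aryl replacement in the methylamino-quinazoline anilide series

This account rests on a few compounds, and the source may have more. Where it says the series, first, only, none or still open, it means among the compounds named here.

Measured compounds:
compound 1 `CNc1ncnc2c(CNc3cc(NC(=O)c4cccc(C(F)(F)F)c4)ccc3C)cccc12`: 433 nM
compound 2 `CNc1ncnc2c(CNc3cc(NC(=O)c4ccc(Cl)c(C(F)(F)F)c4)ccc3C)cccc12`: 9700 nM

In a functional assay on A375P cells (Homo sapiens) for cytotoxicity, read by MTT assay, with a stated time of 24 h (on this read-out higher numbers stand for weaker inhibition and lower numbers for stronger inhibition), compound 2 stands with the highest number of the two measured, its nearest neighbour being compound 1, from which it is separated by a 22-fold higher number from compound 1 to compound 2 (1.35 log units; beyond the scatter). Compound 3 `CNc1ncnc2c(CNc3cc(NC(=O)c4ccnnc4)ccc3C)cccc12` is not yet measured. It differs from compound 2 by pyridazin-4-yl in place of 4-chloro-3-(trifluoromethyl)phenyl on a carbonyl carbon.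

Among the measured compounds shown here, only one measured step exists, and it bears on the change only indirectly: adding a chloro to the aromatic ring of the amide gave a 22-fold higher number from compound 1 to compound 2 (1.35 log units; beyond the scatter), a large shift. For the measured compounds named here, the change to compound 3 removes that chloro together with the trifluoromethyl and exchanges the ring itself, so no measured pair covers it directly. Given that compound 2 lies far from compound 1, a step back towards the lower number is expected, but of uncertain size; compound 3 is estimated at 4000 nM in this assay, range 700 nM to 25000 nM, corresponding to an expected 2.4-fold lower number from compound 2 to compound 3 (0.38 log units; beyond the scatter).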

Compound 3, half-maximal inhibitory concentration: 61700 nM
The estimate for compound 3 lay 15-fold (1.19 log units) below the measured number; measured number above the stated range.
By their numbers in this assay, from the lowest: compound 1; then compound 2; then compound 3.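

In this assay, the amide aryl group on the carbonyl carbon does not behave as a simple matter of the chloro: pyridazin-4-yl in place of 4-chloro-3-(trifluoromethyl)phenyl removes that chloro, yet gives a 6.4-fold higher number from compound 2 to compound 3 (0.80 log units; beyond the scatter) rather than a return towards compound 1. Measured against the unchlorinated anilide, the same ring gives a 140-fold higher number from compound 1 to compound 3 (2.15 log units; beyond the scatter) and this is the largest step in the three-compound set, with compound 3 at the top of the order. No measurement at hand explains either step.

The exchange of ring and the loss of trifluoromethyl occur together here, so their separate contributions remain unresolved. An unsubstituted phenyl, or a pyridazin-4-yl ring carrying trifluoromethyl, would be needed to separate them.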